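Hydroxy on the saturated ring: from compound 1 to compound 3

The source may hold more compounds than are shown below. What is called first, only, known or untested is meant among the compounds shown, and "the series" means these compounds.

Measured so far in a functional assay on the whole organism for inhibition, with Mus musculus as the target, at a dose of 30 mg/kg by the oral route; on this read-out higher numbers stand for more inhibition at the one dose given (going by the name of the read-out) and lower numbers for less inhibition:
compound 1 `O=C(NCCCOc1ccc2nc(O)ccc2c1)N(C1CCCCC1)C1CC1`: 100%
compound 2 `O=C(NCCCOc1ccc2nc(O)ccc2c1)N(C1CC1)[C@@H]1CCC[C@@H](O)C1`: 20%

In this assay compound 1 gives 100%, the higher of the two numbers shown; compound 2 gives 20%. Going by the values given here, the one step between them is a number 80 percentage points lower from compound 1 to compound 2 (beyond the scatter), a large drop beyond the scatter.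

Compound 3 `O=C(NCCCOc1ccc2nc(O)ccc2c1)N(C1CC1)[C@H]1CCCC[C@@H]1O` differs from compound 1 by hydroxy in place of hydrogen on a saturated ring carbon. Among the compounds with values here, the only measured step that bears on this change is the one to compound 2, with the same kind of alteration, and it was large and downward. A downward step of similar size is therefore expected. Compound 3 is expected to give about 35% in this assay, within 10% to 70%. The expected step is a number 65 percentage points lower from compound 1 to compound 3 (beyond the scatter).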

Compound 3, a percentage reported as inhibition, in the whole organism at one dose (the size of the read-out at that dose, not a potency): 100%
The estimate for compound 3 lay 65 percentage points below the measured number; measured number outside the range, above it.
By their numbers in this assay, from the lowest: compound 2; then compounds 1 and 3 (each within the scatter of the next).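

In this assay the change from cyclohexyl to 2-hydroxycyclohexyl gives no change at the digits printed from compound 1 to compound 3 (within the scatter) and so shows that hydroxy on this ring does not by itself lower the read-out. The two hydroxylated compounds stand far apart, with a number 80 percentage points higher from compound 2 to compound 3 (beyond the scatter) on going from 3-hydroxycyclohexyl to 2-hydroxycyclohexyl, so the earlier loss is specific to compound 2 and does not extend to every hydroxy on this ring. No measurement at hand accounts for that gap.

Going by these compounds, whether ring position or stereochemistry separates compound 2 from compound 3 stays open. So does whether methoxy or an amine on the same ring carbon would behave like hydroxy.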